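Swapping the aryl group on the ring amine nitrogen

A few compounds are considered here, and "the series" means these few. Any claim that something is new, unique, unknown or untested is made for them only; others in the source may bear on it.

Two measured compounds share one core and differ only in the aromatic group attached to an amine nitrogen in a ring. In an ADME assay on HEK293 cells for displacement of a labelled ligand from 5-hydroxytryptamine receptor 6 (Homo sapiens), read by radioligand binding, with a stated time of 1 h (on this read-out lower numbers stand for stronger inhibition and higher numbers for weaker inhibition), compound 1 `O=C1c2ccccc2S(=O)(=O)N1CCCCCCN1CCN(c2ccccc2F)CC1` gives 1620 nM, and compound 2 `COc1cccc(N2CCN(CCCCCCN3C(=O)c4ccccc4S3(=O)=O)CC2)c1` gives 921 nM; the step of a 1.8-fold lower number from compound 1 to compound 2 (0.25 log units; within the scatter) therefore lies within the scatter. Compound 3 `O=C1c2ccccc2S(=O)(=O)N1CCCCCCN1CCN(c2ccccc2C(F)(F)F)CC1` carries 2-(trifluoromethyl)phenyl in place of 3-methoxyphenyl on an amine nitrogen in a ring. For the measured compounds named here, only that one measured step bears on this change, and it was small, so no step beyond the scatter is expected for compound 3 in this assay, the expected step being a 1.6-fold higher number from compound 2 to compound 3 (0.21 log units; within the scatter). Compound 3 is estimated at 1500 nM, with a range from 500 nM to 4500 nM.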

Compound 3, inhibition constant: 1270 nM
Estimate against measurement, compound 3: 1.2-fold (0.07 log units) above; the measured number falls inside the stated range.
By their numbers in this assay, from the lowest: compounds 2, 3 and 1 (each within the scatter of the next).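

In this assay, the exchange of aryl groups gives a 1.4-fold higher number from compound 2 to compound 3 (0.14 log units; within the scatter), while trifluoromethyl in place of fluoro on an aromatic carbon gives a 1.3-fold lower number from compound 1 to compound 3 (0.11 log units; within the scatter). All three aryl groups on this ring amine nitrogen therefore stand within the scatter of one another, so neither new comparison separates them. No evidence here explains why these steps are so small. Still open, as far as these compounds go, is whether a phenyl ring bearing an amine or a carboxylic acid would give a step beyond the scatter. From the compounds shown here alone, a longer chain in the shared core is equally open.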